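The source may report more compounds than this note shows. Statements on the series, on what has been measured and on what is new or still open speak of the compounds shown alone.

Measured so far: compound 1 `O=C(O)c1ccc(Cl)cc1-c1ccc2c(c1)OC[C@H](Cc1ccc(F)cc1)[C@H]2O` with 54 nM; compound 2 `O=C(O)c1ccc(Cl)cc1-c1ccc2c(c1)OC[C@H](Cc1ccc(C(F)(F)F)cc1)[C@H]2O` with 400 nM.

In an assay on isolated protein for binding affinity to leukotriene B4 receptor (Homo sapiens) (a lower number here means a stronger inhibitor, a higher number a weaker inhibitor), compound 2 gives 400 nM and stands highest of the two numbers; the nearest is compound 1, which gives 54 nM. Compound 3 `O=C(O)c1ccc(Cl)cc1-c1ccc2c(c1)OC[C@H](Cc1ccc3ccccc3c1)[C@H]2O` differs from compound 2 by naphthalen-2-yl in place of 4-(trifluoromethyl)phenyl on a saturated chain carbon bound to a saturated ring carbon. Within the data shown here, the only measured step, a 7.4-fold higher number from compound 1 to compound 2 (0.87 log units; beyond the scatter), alters the same side chain and is the sole guide here; it shows the chain tolerates change only modestly. The expected step is a 2.0-fold lower number from compound 2 to compound 3 (0.30 log units; within the scatter), its direction uncertain. Compound 3 is estimated at 200 nM, within a range from 50 nM to 800 nM.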

Compound 3, half-maximal inhibitory concentration: 100 nM
For compound 3 the middle estimate is 2.0-fold (0.30 log units) above the measured one; the measured number falls inside the stated range.
By their numbers in this assay, from the lowest: compounds 1 and 3 (each within the scatter of the next); then compound 2.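

In this assay, a second aromatic ring of carbon only is accepted on the saturated chain carbon bound to a saturated ring carbon: the replacement of 4-(trifluoromethyl)phenyl gives a 4.0-fold lower number from compound 2 to compound 3 (0.60 log units; beyond the scatter) and the replacement of 4-fluorophenyl gives a 1.9-fold higher number from compound 1 to compound 3 (0.27 log units; within the scatter) so naphthalen-2-yl and 4-fluorophenyl cannot be told apart here. Since 4-(trifluoromethyl)phenyl and naphthalen-2-yl have the same heavy-atom count, that count alone does not set the number. No measurement offered here accounts for the difference. On these data alone, whether an amine or a carboxylic acid on the aromatic ring, or a longer chain leading to it, is accepted stays open.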